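The compounds below may be only part of what the source reports. "The series", "measured", "known", "first", "only" and "open" are said of these compounds alone.

Measured so far in a functional assay on the whole organism (Tail, strain ICR) with Mus musculus as the target, in the tail flick test, with a stated time of 150 min, at a dose of 25 umol/kg by the oral route; on this read-out higher numbers stand for a stronger effect at the one dose given and lower numbers for a weaker effect:
compound 1 `O=C(CN(c1nc(Cl)nc2[nH]cnc12)C1CC1)NCC(=O)OCc1ccccc1` gives 18%
compound 2 `O=C(OCc1ccccc1)[C@@H]1CCCN1C(=O)CN(c1nc(Cl)nc2[nH]cnc12)C1CC1` gives 31.1%

Compound 1 stands lowest of the two numbers; its nearest neighbour, compound 2, reads higher by a margin beyond the usual scatter. For the measured compounds named here, no pair of measured compounds differs in a single place, so no step can be read off within the measured set: the two values show only that compound 2 sits higher than compound 1, with several differences between them at once.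

Compound 3 `O=C(CN(c1nc(Cl)nc2[nH]cnc12)C1CC1)N[C@@H](CC(=O)OCc1ccccc1)C(=O)OCc1ccccc1` is not yet measured. Relative to compound 1 it carries (benzyloxycarbonyl)methyl in place of hydrogen on a saturated chain carbon bound to an amide-type nitrogen and a carbonyl carbon; the shared core and the remainder of compound 1 are kept. The only measured reference with more than compound 1 in the amide-linked part is compound 2, which gives 31.1%, and on that thin basis a modest upward step in this assay is expected, though a step within the scatter is nearly as plausible and a fall cannot be excluded. Compound 3 is therefore estimated at 26%, within 10% to 45%, an expected step of a number 8 percentage points higher from compound 1 to compound 3 (within the scatter).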

Compound 3, a percentage reported as activity, at one dose (the size of the read-out at that dose, not a potency): 6.68%
Estimate against measurement, compound 3: 19.3 percentage points above; measured number outside the range, below it.
By their numbers in this assay, from the lowest: compound 3; then compound 1; then compound 2.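

In this assay, for the compounds shown here, (benzyloxycarbonyl)methyl in place of hydrogen on a saturated chain carbon bound to an amide-type nitrogen and a carbonyl carbon gives the first single-place comparison, a step of a number 11.3 percentage points lower from compound 1 to compound 3 (beyond the scatter). The change at this position therefore lowers the read-out by more than the usual scatter, which the earlier pair, differing in several places at once, could not show. Nothing measured on these compounds accounts for the step.

As far as these compounds go, whether the lower number belongs to the (benzyloxycarbonyl)methyl group as a whole or to any substitution at this carbon remains open, and a methyl group or a carboxylic acid on a short chain at the same place would separate those two readings. Also open, from the compounds shown here alone, is how the same change behaves when the rest of the molecule differs, and, with a single dose and a single time in this read-out, whether the step reflects a change in potency or only in the size of the effect at that dose.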